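A few compounds are considered here, and "the series" means these few. Any claim that something is new, unique, unknown or untested is made for them only; others in the source may bear on it.

Measured compounds:
- compound 1 `O=C(Nc1ccc(Cl)c(-c2nnc3c(Cl)cccn23)c1)c1ccccn1`: > 100000 nM
- compound 2 `O=C(Nc1ccc(Cl)c(-c2nnc3c(Cl)cccn23)c1)c1ccc(Cl)cc1`: 73600 nM
- compound 3 `O=C(Nc1ccc(Cl)c(-c2nnc3c(Cl)cccn23)c1)c1ccon1`: 42700 nM

All three share one core and differ only in the group on the carbonyl carbon of the amide. In a functional assay on A549 cells (Homo sapiens) for antiproliferative activity, read by MTT assay, with a stated time of 72 h (on this read-out higher numbers stand for weaker inhibition and lower numbers for stronger inhibition), compound 1 reaches only the limit of the assay, > 100000 nM, which is a limit and not a number (the limit of > 100000 nM in this assay, at which 1 of the 3 values shown sits). In this assay compound 2 gives 73600 nM, the higher of the two numbers shown, yet compound 2 and compound 3 are not really separated, since a 1.7-fold lower number from compound 2 to compound 3 (0.24 log units; within the scatter). Compound 3 gives 42700 nM in this assay. For the measured compounds named here, the remaining steps are an at least 1.3-fold lower number from compound 1 to compound 2 (0.13 log units; that floor lies within the scatter) and an at least 2.3-fold lower number from compound 1 to compound 3 (0.36 log units; beyond the scatter), so every exchange of the aryl group on the carbonyl carbon seen so far has moved the number little, and only the one from compound 1 to compound 3 clears the scatter.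

Compound 4 `CS(=O)(=O)c1cccc(C(=O)Nc2ccc(Cl)c(-c3nnc4c(Cl)cccn34)c2)c1` is the next variant at the same position: 3-(methylsulfonyl)phenyl in place of 4-chlorophenyl on a carbonyl carbon. Going by the values given here, the steps that bear on it are those from compound 2, namely a 1.7-fold lower number from compound 2 to compound 3 (0.24 log units; within the scatter), and the one into compound 2, an at least 1.3-fold lower number from compound 1 to compound 2 (0.13 log units; that floor lies within the scatter); both are small. Among the compounds with values here, nothing among the measured compounds points to a large move in either direction, so the account expects a step of a 1.2-fold lower number from compound 2 to compound 4 (0.09 log units; within the scatter) that stays within the scatter. The estimate for compound 4 in this assay is therefore 60000 nM, expected to lie between 20000 nM and 180000 nM.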

Compound 4, half-maximal inhibitory concentration: > 100000 nM
Compound 4 was reported as a limit; the forecaster's own chance of this, stated with the estimate: 35%; middle value at least 1.6-fold (0.22 log units) away from the limit.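

For the compounds shown here, replacing 1,2-oxazol-3-yl with 3-(methylsulfonyl)phenyl on the carbonyl carbon gives an at least 2.3-fold higher number from compound 3 to compound 4 (0.36 log units; beyond the scatter), so this position now has a change that raises the number beyond the scatter, which none of the earlier steps showed in that direction. Replacing 4-chlorophenyl with the same group gives an at least 1.3-fold higher number from compound 2 to compound 4 (0.13 log units; that floor lies within the scatter), so this change may be small or much larger, and the step between the two compounds that both stand at a limit cannot be read. In this assay compound 4 is reported as a limit and not a number, as compound 1 is, so the top of the range now holds more than one variant at this position: the limit of > 100000 nM in this assay, at which 2 of the 4 values shown sit.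

The compounds shown leave open how far compound 4 lies beyond its limit, and so how large the loss from the 3-(methylsulfonyl)phenyl group really is. They also leave open whether an amine or a carboxylic acid on the phenyl ring, in place of the methylsulfonyl group, would give a number that could be read in this assay.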